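The source may report more compounds than this note shows. Statements on the series, on what has been measured and on what is new or still open speak of the compounds shown alone.

Compound 1 `c1ccc(/N=N/N2CCOCC2)cc1` carries only a bare phenyl ring on the shared core. In an assay on cells for inhibition of cytochrome P450 1A1 (Homo sapiens), read by fluorescence, using NADPH, with a stated time of 2 min (a lower number here means a stronger inhibitor, a higher number a weaker inhibitor), compound 1 gives 120000 nM, the highest number of the two measured here and so the weakest inhibition. Its only measured companion, compound 2 `COc1cc(/N=N/N2CCOCC2)cc(OC)c1OC`, with three methoxy groups on that ring, gives 10000 nM in this assay, a clearly lower number that lies beyond the scatter. Compound 3 `CC(=O)c1ccc(/N=N/N2CCOCC2)cc1` has not been measured in this assay. Its difference from compound 1 is acetyl in place of hydrogen on an aromatic carbon. Among the measured compounds shown here, no measured pair here shows this exact change, so the expected step rests on the observation that substituting the ring, as in compound 2 with 10000 nM, lowered the number. For compound 3 the estimated step of a 3.0-fold lower number from compound 1 to compound 3 (0.48 log units; beyond the scatter) is therefore expected to be downward, modest, and probably beyond the scatter. Compound 3 is expected to give about 40000 nM, within a range from 10000 nM to 150000 nM.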

Compound 3, half-maximal inhibitory concentration: 82000 nM
Estimate against measurement, compound 3: 2.1-fold (0.31 log units) below; the range from low to high includes it.
By their numbers in this assay, from the lowest: compound 2; then compounds 3 and 1 (each within the scatter of the next).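

Acetyl in place of hydrogen on an aromatic carbon, para to a group of 8 heavy atoms, gives the only one-place comparison in this assay so far, with a 1.5-fold lower number from compound 1 to compound 3 (0.17 log units; within the scatter) as its step. At this position, then, acetyl gives a reading that cannot be told apart from that of the bare phenyl ring, so putting a group on the ring does not by itself guarantee a clear change in this assay. Nothing measured here bears on why the step is this small.

Going by these compounds, whether an amine, a carboxylic acid or a longer chain at this same position would move the number beyond the scatter remains open. Also open, on these data alone, is whether a single methoxy group there would do so, since compound 2 carries three.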